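The source may report more compounds than this note shows. Statements on the series, on what has been measured and on what is new or still open speak of the compounds shown alone.

Measured compounds:
Compound 1, `O=c1ccoc2cc(OCc3cn(Cc4cccc(F)c4)nn3)ccc12`, in a functional assay on SW480 cells (Homo sapiens) for cytotoxicity, read by MTT assay, with a stated time of 48 h (on this read-out lower numbers stand for stronger inhibition and higher numbers for weaker inhibition), gives > 100000 nM, which is a limit of the assay rather than a number.
Compound 2, `O=c1ccoc2cc(OCc3cn(Cc4ccc(Cl)cc4Cl)nn3)ccc12`, in this assay gives > 100000 nM, likewise a limit of the assay.

Within the data shown here, compound 1 therefore stands only at a limit in this assay, as does the single other measured compound. The step that the two limits leave unreadable from compound 1 to compound 2 cannot be read in size because the limit of > 100000 nM in this assay, at which 2 of the 2 values shown sit, is where both values sit. Compound 3, `O=c1ccoc2cc(OCc3cn(Cc4ccc(Cl)cc4)nn3)ccc12`, differs from compound 1 by 4-chlorophenyl in place of 3-fluorophenyl on a saturated chain carbon bound to an aromatic nitrogen. Among the measured compounds shown here, the only measured step touching this part of the structure is the unreadable one just described, so no step beyond the scatter is expected in this assay in either direction, and a further limit is the most likely outcome. The estimate for compound 3 is 150000 nM, with an expected range from 60000 nM to 400000 nM, corresponding to an expected step that the limit leaves unreadable from compound 1 to compound 3.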

Compound 3, half-maximal inhibitory concentration: > 100000 nM
Compound 3: a limit, no number (the forecaster's own chance of this, stated with the estimate: 85%); the middle value is on the limit's open side.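

Compound 3 also stops at a limit in this assay, so its steps from compound 1 and compound 2 cannot be read, because all three compounds share one limit: the limit of > 100000 nM in this assay, at which 3 of the 3 values shown sit.

The compounds shown leave open how these three rank against one another and whether any group in this place gives a measurable value.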